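Removing the benzyl group from the pyrazole nitrogen

The compounds below may be only part of what the source reports. "The series", "measured", "known", "first", "only" and "open" are said of these compounds alone.

Three compounds have been measured so far in a functional assay on PC-3 cells (Homo sapiens) for cytotoxicity, read by MTT assay, with a stated time of 72 h; on this read-out lower numbers stand for stronger inhibition and higher numbers for weaker inhibition:

Compound 1 `Cn1nc(-c2ccccc2)c2cc(C(=N)Nc3ccccc3)ncc21` gives 17300 nM.
Compound 2 `N=C(Nc1ccccc1)c1cc2c(-c3ccccc3)n[nH]c2c(NC2CCCCC2)n1` gives 1730 nM.
Compound 3 `COc1ccc(Cn2nc(-c3ccccc3)c3cc(C(=N)Nc4ccccc4)ncc32)cc1` gives 6300 nM.

Among these three numbers compound 3 stands second highest. Its nearest neighbour is compound 1, whose number is higher, and the lowest number belongs to compound 2, which also carries a cyclohexylamino group on its core that the other two lack.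

The next compound, compound 4 `N=C(Nc1ccccc1)c1cc2c(-c3ccccc3)n[nH]c2cn1`, is compound 3 with hydrogen in place of 4-methoxybenzyl on an aromatic nitrogen. Going by the values given here, only one measured step touches this nitrogen: a 2.7-fold lower number from compound 1 to compound 3 (0.44 log units; beyond the scatter), a modest gain from adding the 4-methoxyphenyl part of the benzyl group. Among the compounds with values here, the change now under consideration removes the whole benzyl group, leaving bare hydrogen, a situation that none of the measured pairs isolates, since compound 2 differs from compound 4 at a second position as well. Within the data shown here, the only guide is that the larger group on this nitrogen did somewhat better than the smaller one in the one step recorded, so in this assay a small rise in the number, close to or just beyond the scatter, is expected: a 1.4-fold higher number from compound 3 to compound 4 (0.15 log units; within the scatter). Compound 4 is therefore estimated at 9000 nM, within a range of 2500 nM to 30000 nM.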

Compound 4, half-maximal inhibitory concentration: 23000 nM
Estimate against measurement, compound 4: 2.6-fold (0.41 log units) below; the range from low to high includes it.
By their numbers in this assay, from the lowest: compound 2; then compound 3; then compounds 1 and 4 (each within the scatter of the next).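

In this assay, hydrogen on the aromatic nitrogen loses the gain seen with the larger group, with a 3.7-fold higher number from compound 3 to compound 4 (0.56 log units; beyond the scatter), whereas exchanging methyl for hydrogen at the same nitrogen stays inside the usual scatter, with a 1.3-fold higher number from compound 1 to compound 4 (0.12 log units; within the scatter). Among the three groups compared on this nitrogen, then, only 4-methoxybenzyl stands apart, while methyl and hydrogen cannot be told apart. The other position carries a larger step than either of these, for losing the cyclohexylamino group on the aromatic carbon gives a 13-fold higher number from compound 2 to compound 4 (1.12 log units; beyond the scatter), so in this small set that carbon matters more than the nitrogen.

No supporting measurement accompanies these numbers, so the reason for the difference in step size remains unexplained. Still open, on these data alone, is whether plain benzyl or a longer chain such as butyl on the nitrogen would match 4-methoxybenzyl, whether a smaller amine such as methylamino on the carbon would keep the gain from cyclohexylamino, and whether the two larger groups would add up if placed together on the shared core.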